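A Hydrazide Replaces the Ethyl Amide

A few compounds are considered here, and "the series" means these few. Any claim that something is new, unique, unknown or untested is made for them only; others in the source may bear on it.

Of the compounds shown here, two sharing one core have been measured in a physicochemical assay for solubility, read by HPLC, in phosphate buffer, with a stated time of 4 h, at pH 7.4; on this read-out lower numbers stand for lower solubility and higher numbers for higher solubility. Compound 1 `COCCOC(=O)c1cc(N)c(Nc2ccc(C#N)cc2)cc1Oc1c(C)cc(/C=C/C#N)cc1C` gives 0.77 ug/mL. Compound 2 `CCNC(=O)c1cc(N)c(Nc2ccc(C#N)cc2)cc1Oc1c(C)cc(/C=C/C#N)cc1C` gives 1.08 ug/mL in this assay, so the two numbers sit within the scatter of each other. Within the data shown here, the only step known so far, a 1.4-fold higher number from compound 1 to compound 2 (0.15 log units; within the scatter), bears loosely on the next change. Compound 3 `Cc1cc(/C=C/C#N)cc(C)c1Oc1cc(Nc2ccc(C#N)cc2)c(N)cc1C(=O)NN` differs from compound 2 by amino in place of ethyl on an amide-type nitrogen. Among the measured compounds shown here, with that single small step as the only guide, a step of a 1.4-fold higher number from compound 2 to compound 3 (0.14 log units; within the scatter) is expected, not beyond the scatter. Compound 3 is therefore estimated at 1.5 ug/mL, with a range from 0.5 ug/mL to 5 ug/mL.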

Compound 3, solubility: 2.4 ug/mL
Compound 3: the middle estimate sits 1.6-fold (0.20 log units) below what was measured, within the range that was stated.
By their numbers in this assay, from the lowest: compounds 1 and 2 (each within the scatter of the next); then compound 3.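

In this assay, amino in place of ethyl on the amide-type nitrogen gives a 2.2-fold higher number from compound 2 to compound 3 (0.35 log units; beyond the scatter), so a change at this position can move the number beyond the scatter, which the earlier pair did not show. Set against the 2-methoxyethoxy group on the carbonyl carbon, aminoamino gives a 3.1-fold higher number from compound 1 to compound 3 (0.49 log units; beyond the scatter), though both steps remain modest. Nothing at hand says why the number rises. Still open, going by these compounds, is whether the step belongs to amino alone: a hydroxyl or methyl group on that nitrogen, or a longer chain ending in an amine, would test this.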